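This account rests on a few compounds, and the source may have more. Where it says the series, first, only, none or still open, it means among the compounds named here.

Compound 3 `CC(=O)Nc1cccc(C(=O)N2CCCC(C(=O)Nc3ccc(Cl)cc3)C2)c1` stands second highest of the three measured compounds in an ADME assay on PC-3 cells (Homo sapiens) for cytotoxicity, read by WST assay, tested at 100 uM (a higher number here means more inhibition at the concentration tested (going by the name of the read-out), a lower number less inhibition), where compound 3 gives 4%. Compound 2 `O=C(Nc1ccc(Cl)cc1)C1CCCN(C(=O)c2cccc([N+](=O)[O-])c2)C1` gives 0%, and compound 1 `O=C(Nc1ccc(Cl)cc1)C1CCCN(C(=O)c2cccc(-c3nccs3)c2)C1` gives 32%. Compound 4 `N#Cc1cccc(C(=O)N2CCCC(C(=O)Nc3ccc(Cl)cc3)C2)c1` differs from compound 3 in one place: cyano in place of acetamido on an aromatic carbon. Going by the values given here, two measured steps bear on this change. Replacing the thiazolyl group by acetamido gave a number 28 percentage points lower from compound 1 to compound 3 (beyond the scatter), a step beyond the scatter, whereas replacing nitro by acetamido gave a number 4 percentage points higher from compound 2 to compound 3 (within the scatter), which lies within it. Since the change here again exchanges one group for another at the same aromatic carbon and both compound 2 and compound 3 sit low, the step of a number 1 percentage points higher from compound 3 to compound 4 (within the scatter) is expected to stay within the scatter. Compound 4 is therefore estimated at 5%, in a range from 0% to 20%.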

Compound 4, a percentage reported as inhibition, at one concentration (the size of the read-out at that concentration, not a potency): 0%
Compound 4: the middle estimate sits 5 percentage points above what was measured, and the stated range covers the measured number.
By their numbers in this assay, from the lowest: compounds 2, 4 and 3 (each within the scatter of the next); then compound 1.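

In this assay cyano in place of acetamido gives a number 4 percentage points lower from compound 3 to compound 4 (within the scatter) and cyano in place of nitro gives no change at the digits printed from compound 2 to compound 4 (within the scatter) so these three groups on this aromatic carbon cannot be told apart. Cyano in place of 1,3-thiazol-2-yl gives a number 32 percentage points lower from compound 1 to compound 4 (beyond the scatter) which leaves compound 1 apart from the other three compounds. Nothing available here accounts for that gap. Still open, from the compounds shown here alone, is whether a phenyl ring on this carbon would stand with compound 1 or with the other three, and where an amine or a carboxylic acid there would fall.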